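From fluoro to chloro at the limit of an assay

The compounds below may be only part of what the source reports. "The series", "measured", "known", "first", "only" and "open" are said of these compounds alone.

Compound 1 `O=C1CCCCC/C1=C\c1ccccc1`: > 50000 nM
Compound 2 `O=C1CCCCC/C1=C\c1cccc(F)c1`: > 50000 nM
Compound 3 `O=C1CCCCC/C1=C\c1cccc(Cl)c1`: not yet measured

In a functional assay on P388 cells (Mus musculus) for inhibition (a higher number here means a weaker inhibitor, a lower number a stronger inhibitor), compound 1 gives > 50000 nM, which is a limit and not a number. Compound 2 gives > 50000 nM, which is also a limit and not a number. Both compounds therefore rest at the limit of > 50000 nM in this assay, at which 2 of the 2 values shown sit, and compound 2 has no numerical position of its own.

Compound 3 differs from compound 2 by one change: chloro in place of fluoro on an aromatic carbon. Among the compounds with values here, only one measured step bears on it, a step that the two limits leave unreadable from compound 1 to compound 2, which also changes the group on an aromatic carbon. Its size cannot be read, so it offers no measured size or direction to carry over. No step beyond the scatter is therefore expected in this assay. The expectation rests on compound 2, with > 50000 nM, a limit of the assay. The expected step is a number no higher from compound 2 to compound 3 (the limit leaves the size open). Compound 3 is estimated at 50000 nM, with an expected range from 20000 nM to 100000 nM, and it may well be reported only as a limit.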

Compound 3, half-maximal inhibitory concentration: 25700 nM
Beside the measured number, compound 3's estimate is 1.9-fold (0.29 log units) above it, within the range that was stated.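

In this assay compound 3 gives 25700 nM, a number and not a limit, which makes it the first of the compounds shown with a position of its own in the assay. Chloro in place of fluoro on this aromatic carbon gives an at least 1.9-fold lower number from compound 2 to compound 3 (0.28 log units; that floor lies within the scatter), and chloro in place of hydrogen gives an at least 1.9-fold lower number from compound 1 to compound 3 (0.28 log units; that floor lies within the scatter), so each step has a floor but no upper end, and neither floor goes beyond the scatter on its own. The step from hydrogen to fluoro still cannot be read, and the full size of both new steps stays hidden for the same reason: the limit of > 50000 nM in this assay, at which 2 of the 3 values shown sit.

The compounds shown leave open how a bromo or a methoxy group on the same aromatic carbon would read in this assay, and whether chloro on another carbon of the aromatic ring would also give a number. They also leave open what an amine in place of the carbonyl of the shared core would do to the value of compound 3.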